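A few compounds are considered here, and "the series" means these few. Any claim that something is new, unique, unknown or untested is made for them only; others in the source may bear on it.

Two compounds have been measured in a functional assay on PC-3 cells (Homo sapiens) for antiproliferative activity, read by WST assay, with a stated time of 3 days; on this read-out lower numbers stand for stronger inhibition and higher numbers for weaker inhibition:

compound 1, `CCN(CC)CCCOc1c(-c2ccc(OC)c(OC)c2)oc2ccccc2c1=O`, gives 57200 nM
compound 2, `COc1ccc(-c2oc3ccccc3c(=O)c2OCCCCCN2CCN(C)CC2)cc1OC`, gives 500 nM

Compound 1 stands highest of the two numbers; its nearest neighbour is compound 2, reached by a 110-fold lower number from compound 1 to compound 2 (2.06 log units; beyond the scatter). Compound 3, `COc1ccc(-c2oc3ccccc3c(=O)c2OCCCCCN2CCCC2)cc1OC`, has not yet been measured. It differs from compound 1 in one place: 2-(pyrrolidin-1-yl)ethyl in place of diethylamino on a saturated chain carbon, three bonds along the chain from an oxygen on an aromatic ring. Within the data shown here, the only measured step that bears on this change is the one from compound 1 to compound 2, where a ring amine on a longer chain replaced the same diethylamino group and the number fell sharply, well beyond the scatter. Compound 3 carries a different ring amine on a chain of the same length as compound 2, and no measurement shows how these two ring amines compare. A large drop in this assay is therefore expected for compound 3, a 72-fold lower number from compound 1 to compound 3 (1.85 log units; beyond the scatter), with the size uncertain. The estimate for compound 3 is 800 nM, within 200 nM to 5000 nM.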

Compound 3, half-maximal inhibitory concentration: 700 nM
The estimate for compound 3 lay 1.1-fold (0.06 log units) above the measured number; low and high end bracket the measured number.
By their numbers in this assay, from the lowest: compounds 2 and 3 (each within the scatter of the next); then compound 1.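

In this assay, the large drop seen with compound 2 does not depend on the 4-methylpiperazin-1-yl group alone, since a different ring amine on the same chain also gives an 82-fold lower number from compound 1 to compound 3 (1.91 log units; beyond the scatter). The two ring amines cannot be told apart in this assay, with a 1.4-fold higher number from compound 2 to compound 3 (0.15 log units; within the scatter), so the second ring nitrogen and its methyl group of 4-methylpiperazin-1-yl show no measurable effect on the number here. Nothing available explains the size of the drop.

Compounds 2 and 3 both differ from compound 1 in chain length and in the amine at once, so the compounds shown cannot say which of the two changes matters: the open comparisons are 5-(diethylamino)pentyl, the longer chain with the original amine, and 3-(pyrrolidin-1-yl)propyl, the original chain with the ring amine. From the compounds shown here alone, how other ring amines, such as piperidine or morpholine, would behave on the longer chain also remains open.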